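Swapping the Nitroxide Cap in a Peptide Prodrug Series

The compounds below may be only part of what the source reports. "The series", "measured", "known", "first", "only" and "open" are said of these compounds alone.

Compound 1 `CC(ON(C(C)(C)C)C(C)(C)C)c1ccc(NC(=O)[C@@H](NC(=O)[C@@H]2CCCN2C(=O)[C@H](C)NC(=O)[C@H](C)NC(=O)CCC(=O)O)C(C)C)cc1` is a peptide-like molecule that carries a succinyl tail and, at its other end, an oxygen-linked bis(tert-butyl)amino group. In a functional assay on U-87MG ATCC cells for cytotoxicity against U-87 MG (Homo sapiens), with a stated time of 72 h, in the presence of a further agent that is not named here (a lower number here means that less compound is tolerated, a higher number that more compound is tolerated), compound 1 gives 150000 nM. Compound 2 `CC(ON1C(C)(C)CCCC1(C)C)c1ccc(OC(=O)[C@@H](NC(=O)[C@@H]2CCCN2C(=O)[C@H](C)NC(=O)[C@H](C)NC(=O)CCC(=O)O)C(C)C)cc1` holds a 2,2,6,6-tetramethylpiperidin-1-yl on that oxygen and an ester in place of the amide; in this assay compound 2 gives 150000 nM, and on the digits shown compound 1 and compound 2 stand level, within the usual scatter.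

Compound 3 `CC(ON1C(C)(C)CCCC1(C)C)c1ccc(NC(=O)[C@@H](NC(=O)[C@@H]2CCCN2C(=O)[C@H](C)NC(=O)[C@H](C)NC(=O)CCC(=O)O)C(C)C)cc1` has not been measured. It is derived from compound 1 by one change (2,2,6,6-tetramethylpiperidin-1-yl in place of bis(tert-butyl)amino on an oxygen on a saturated carbon), which keeps the amide link of compound 1.

Nothing measured shows this change acting on its own, so no step beyond the scatter is expected; the value is estimated to move by no change at the digits printed from compound 1 to compound 3 (within the scatter). Compound 3 is therefore expected to come out near 150000 nM, with a likely range from 75000 nM to 300000 nM.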

Compound 3, concentration lethal to 50% of the cells: 150000 nM
Estimate against measurement, compound 3: no gap at the digits printed; the range from low to high includes it.
By their numbers in this assay, from the lowest: compounds 1, 2 and 3 (each within the scatter of the next).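

For the compounds shown here, replacing bis(tert-butyl)amino with 2,2,6,6-tetramethylpiperidin-1-yl on an oxygen on a saturated carbon, with the amide link kept, reads in this assay as no change at the digits printed from compound 1 to compound 3 (within the scatter) and this is the first reading of that change on its own. Compound 3 also differs from compound 2 in one place only, an amide where compound 2 has an ester, and the printed values of compound 2 and compound 3 are the same (150000 nM). No supporting measurement is available to explain this result.

From the compounds shown here alone, whether a diethylamino or a morpholin-4-yl group on that oxygen would also stand level with these compounds remains open. The compounds shown also leave open whether any group in this place can move the value in this assay at all.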